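Trimming a Methyl from the Saturated Ring of Compound 2

The compounds below may be only part of what the source reports. "The series", "measured", "known", "first", "only" and "open" are said of these compounds alone.

Compound 2 `CC1CCN(c2nc(C3CC3)ccc2CNC(=O)C(C)c2ccc(NS(C)(=O)=O)c(F)c2)CC1` gives 0.9 nM in an assay on CHO cells for antagonist activity at transient receptor potential cation channel subfamily V member 1 (Homo sapiens), read by FLIPR (a higher number here means a weaker inhibitor, a lower number a stronger inhibitor), the lowest of the two numbers here. Compound 1 `Cc1ccc(CNC(=O)C(C)c2ccc(NS(C)(=O)=O)c(F)c2)c(N2CCC(C)CC2)n1` gives 72.1 nM in this assay. Within the data shown here, the only measured step is an 80-fold lower number from compound 1 to compound 2 (1.90 log units; beyond the scatter). Compound 3 `CC(C(=O)NCc1ccc(C2CC2)nc1N1CCCCC1)c1ccc(NS(C)(=O)=O)c(F)c1` differs from compound 2 by hydrogen in place of methyl on a saturated ring carbon. That measured step changed a group on an aromatic carbon, not on the saturated ring, so nothing measured bears directly on this change. The loss of one carbon is a small alteration, and the expected step of a 2.2-fold higher number from compound 2 to compound 3 (0.35 log units; beyond the scatter) is modest, its direction uncertain. Compound 3 is therefore estimated at 2 nM, within 0.7 nM to 8 nM.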

Compound 3, inhibition constant: 1.1 nM
Beside the measured number, compound 3's estimate is 1.8-fold (0.26 log units) above it, within the range that was stated.
By their numbers in this assay, from the lowest: compounds 2 and 3 (each within the scatter of the next); then compound 1.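

Going from 4-methylpiperidin-1-yl to piperidin-1-yl gives a 1.2-fold higher number from compound 2 to compound 3 (0.09 log units; within the scatter) in this assay so on this saturated ring carbon, hydrogen can stand in place of methyl with no change beyond the scatter. Among these compounds, this is the first measured change on the saturated ring, as the earlier step concerned a group on an aromatic carbon. Nothing available explains this result. Still open, on these data alone, is whether an amine, a hydroxyl or a longer chain on this carbon would keep the number as low. Also open, as far as these compounds go, is whether the same swap would read alike with methyl instead of cyclopropyl on the aromatic carbon.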